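A few compounds are considered here, and "the series" means these few. Any claim that something is new, unique, unknown or untested is made for them only; others in the source may bear on it.

Three compounds with a shared core, differing only in the group on the sulfur, have been measured so far in a functional assay on MCF7 cells (Homo sapiens) for inhibition, read by MTT assay, with a stated time of 72 h (a higher number here means a weaker inhibitor, a lower number a stronger inhibitor), to date. Compound 1 `Cc1cc(Nc2cc(-c3ccccc3)[nH]n2)n2nc(SCCc3ccccc3)nc2n1` gives 2700 nM and compound 2 `Cc1cc(Nc2cc(-c3ccccc3)[nH]n2)n2nc(SCc3ccccc3Br)nc2n1` gives 3020 nM there, while compound 3 `C#CCSc1nc2nc(C)cc(Nc3cc(-c4ccccc4)[nH]n3)n2n1` gives 21800 nM as the highest number of the three. Its steps to both others lie beyond the scatter, so compound 3 is the weakest inhibitor of the set.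

Compound 4 `Cc1cc(Nc2cc(-c3ccccc3)[nH]n2)n2nc(SCc3csc4ccccc34)nc2n1` differs from it in one place, with 1-benzothiophen-3-yl in place of ethynyl on a saturated chain carbon bound to a sulfur as the whole change. For the measured compounds named here, three measured steps bear on this. Within the scatter lies a 1.1-fold higher number from compound 1 to compound 2 (0.05 log units; within the scatter) and so the benzyl and 2-bromophenyl groups are not told apart. Modest but beyond the scatter are an 8.1-fold higher number from compound 1 to compound 3 (0.91 log units; beyond the scatter) and a 7.2-fold higher number from compound 2 to compound 3 (0.86 log units; beyond the scatter) on going to ethynyl. Going by the values given here, compound 4 again carries an aromatic group, so, reading a 7.2-fold higher number from compound 2 to compound 3 (0.86 log units; beyond the scatter) in reverse, a step of similar size toward a lower number is expected, although no measured compound carries 1-benzothiophen-3-yl. The expected step in this assay is a 7.8-fold lower number from compound 3 to compound 4 (0.89 log units; beyond the scatter) by this estimate. For compound 4 the estimated value is 2800 nM with an expected range from 1000 nM to 8000 nM in this assay.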

Compound 4, half-maximal inhibitory concentration: 3470 nM
Compound 4: the middle estimate sits 1.2-fold (0.09 log units) below what was measured; low and high end bracket the measured number.
By their numbers in this assay, from the lowest: compounds 1, 2 and 4 (each within the scatter of the next); then compound 3.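

In this assay, for the compounds shown here, the step from ethynyl back to an aromatic group on a saturated chain carbon bound to a sulfur now extends to a group that no earlier compound carried, with a 6.3-fold lower number from compound 3 to compound 4 (0.80 log units; beyond the scatter) modest but beyond the scatter. The entering 1-benzothiophen-3-yl group, with its five-membered aromatic ring holding a hetero atom and its six-membered aromatic ring of carbon only, is not told apart from the earlier groups: a 1.1-fold higher number from compound 2 to compound 4 (0.06 log units; within the scatter) and a 1.3-fold higher number from compound 1 to compound 4 (0.11 log units; within the scatter) both lie within the scatter. Compounds 1, 2 and 4 therefore form one level despite their different aromatic groups, and among the compounds shown only the ethynyl of compound 3 stands apart.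

The compounds shown leave open whether an aromatic ring is what matters at this position, and a saturated cyclohexyl ring, a longer plain alkyl chain, an amine or a carboxylic acid on the same chain carbon would each test that. Nothing supplied gives a measured reason for the separation of compound 3 from the other three.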